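A Mirror-Image Change on a Brominated Core

The compounds below may be only part of what the source reports. "The series", "measured", "known", "first", "only" and "open" are said of these compounds alone.

Of the compounds shown here, three sharing a heavily brominated core have been tested in a functional assay on MCF7 cells (Homo sapiens) for antiproliferative activity, read by MTT assay, with a stated time of 48 h, tested at 25 uM; on this read-out higher numbers stand for a weaker effect at the one concentration tested and lower numbers for a stronger effect. Compound 1, `OC(CCn1nc2c(Br)c(Br)c(Br)c(Br)c2n1)c1ccc(F)cc1`, gives 97%. Compound 3, `OC(CCn1nc2c(Br)c(Br)c(Br)c(Br)c2n1)c1ccccc1`, gives 105%. Compound 2, `C[C@@H](O)CCn1nc2c(Br)c(Br)c(Br)c(Br)c2n1`, gives 77%, the lowest number of the three and therefore the strongest effect, since its gaps to compound 1 and to compound 3 both lie beyond the scatter.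

For the measured compounds named here, the only measured step between neighbours, a number 8 percentage points higher from compound 1 to compound 3 (within the scatter), concerns a substituent on an aromatic ring and says nothing about configuration, so it offers no guide for what follows.

Compound 4, `C[C@H](O)CCn1nc2c(Br)c(Br)c(Br)c(Br)c2n1`, is the compound not yet measured. Its difference from compound 2 is this: the two compounds have the same atoms and bonds and differ only in configuration as drawn: 1 of 1 stereo elements differ; a stereocentre at a saturated chain carbon is drawn R in compound 2 and S in compound 4. Going by the values given here, no measured pair in this set shows what such an inversion of a single stereocentre does in this assay. With nothing pointing in either direction, compound 2 and its value 77% serve as the only anchor. For compound 4 the expected step is a number 3 percentage points higher from compound 2 to compound 4 (within the scatter), one that stays within the scatter. Compound 4 is therefore estimated at 80%, with a range from 62% to 100%.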

Compound 4, a percentage reported as activity, at one concentration (the size of the read-out at that concentration, not a potency): 89%
The estimate for compound 4 lay 9 percentage points below the measured number; the measured number falls inside the stated range.
By their numbers in this assay, from the lowest: compound 2; then compounds 4, 1 and 3 (each within the scatter of the next, the first and the last beyond it).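

In this assay, turning the stereocentre at the saturated chain carbon from R to S comes with a number 12 percentage points higher from compound 2 to compound 4 (beyond the scatter), so the S form has the weaker effect at the one concentration tested. Configuration at this carbon therefore matters in its own right, which the earlier step, a change on an aromatic ring, could not show. The shift can be assigned to this single stereocentre because nothing else separates the two compounds: the fact that compounds 2 and 4 differ only in the configuration as drawn

The step is modest and comes from one pair at one concentration, so it gives no measure of potency and no reason for the preference. From the compounds shown here alone, whether the R form would also keep its edge with an amine in place of the hydroxyl or with a longer chain stays open, as does the role of configuration in compound 1 and compound 3, where none is drawn at the carbon bearing the hydroxyl.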